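Iodo in place of chloro: a step behind a limit

A few compounds are considered here, and "the series" means these few. Any claim that something is new, unique, unknown or untested is made for them only; others in the source may bear on it.

In a physicochemical assay for lipophilicity, at pH 7.4 (on this read-out lower numbers stand for lower lipophilicity and higher numbers for higher lipophilicity), compound 1 `O=S(=O)(O)Nc1ccc(-c2nc3ccccc3s2)cc1` gives 7.5. Compound 2 `Cc1cc(-c2nc3ccccc3s2)ccc1NS(=O)(=O)O` gives only a limit, < 3. Compound 3 `O=S(=O)(O)Nc1ccc(-c2nc3ccccc3s2)cc1Cl` also gives only a limit, < 2.19, so its true position on the scale is not known.

The next compound, compound 4 `O=S(=O)(O)Nc1ccc(-c2nc3ccccc3s2)cc1I`, has not yet been measured. It differs from compound 3 by one exchange: iodo in place of chloro on an aromatic carbon. Iodo takes the place of chloro on an aromatic carbon, ortho to a sulfoamino group.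

Among the compounds with values here, three measured steps bear on this exchange. Methyl in place of hydrogen gives a number at least 4.50 log units lower from compound 1 to compound 2 (beyond the scatter). Chloro in place of hydrogen gives a number at least 5.31 log units lower from compound 1 to compound 3 (beyond the scatter). Both steps are large, but both start from hydrogen, whereas here one group replaces another. The closer guide is chloro in place of methyl, which gives a step that the two limits leave unreadable from compound 2 to compound 3.

That guide shows no size, so no step beyond the scatter is expected in this assay, and no direction is favoured. The expected change is a number at least 0.01 log units higher from compound 3 to compound 4 (that floor lies within the scatter). For compound 4 the estimated value is 2.2, with an expected range from 1.2 to 3.2. A limit rather than a number would be no surprise.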

Compound 4, distribution coefficient: 1.9
Compound 4: the middle estimate sits 0.30 log units above what was measured; the range from low to high includes it.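

In this assay, within the data shown here, iodo in place of hydrogen gives a number 5.60 log units lower from compound 1 to compound 4 (beyond the scatter), and this is the first step at this position whose size is a real number rather than a floor set by a limit. The steps from compound 2 and from compound 3 to compound 4 cannot be read, so the data do not rank iodo against methyl or chloro, even though all three groups sit on the same aromatic carbon and each gives a large step down from compound 1. For chloro, this gap exists because compound 3 stands only as a limit: the limit of < 2.19 in this assay, at which 1 of the 4 values shown sits.

On these data alone, for methyl the comparison stays open in the same way, since compound 2 also stands only as a limit: the limit of < 3 in this assay, at which 1 of the 4 values shown sits. Also open is whether a group of another kind at this position, such as an amine or a carboxylic acid, would leave the value close to that of compound 1 or bring it down as methyl, chloro and iodo do.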